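Chloro on the urea aryl ring: HT-29 cytotoxicity notes

The source may hold more compounds than are shown below. What is called first, only, known or untested is meant among the compounds shown, and "the series" means these compounds.

Compound 1 `CCN(CC)CCCNc1nc(-c2ccc(NC(=O)Nc3ccccc3)cc2)nc2c(Cl)c(Cl)sc12` is the unsubstituted-urea parent of the series. In a functional assay on HT-29 cells (Homo sapiens) for cytotoxicity, read by MTT assay, with a stated time of 72 h (on this read-out higher numbers stand for weaker inhibition and lower numbers for stronger inhibition), compound 1 gives 820 nM. Compound 2 `CCN(CC)CCCNc1nc(-c2ccc(NC(=O)Nc3ccc(Cl)cc3)cc2)nc2c(Cl)c(Cl)sc12` carries the change chloro in place of hydrogen on an aromatic carbon and in this assay compound 2 gives 250 nM; the resulting step is a 3.3-fold lower number from compound 1 to compound 2 (0.52 log units; beyond the scatter).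

Compound 3 `CCN(CC)CCNc1nc(-c2ccc(NC(=O)Nc3ccccc3Cl)cc2)nc2c(Cl)c(Cl)sc12` has a different core; how the cores of compound 1 and compound 3 differ is not broken down here. In this assay compound 3 gives 550 nM.

Compound 4 `CCN(CC)CCNc1nc(-c2ccc(NC(=O)Nc3ccc(Cl)cc3Cl)cc2)nc2c(Cl)c(Cl)sc12` is not yet measured. It differs from compound 3 by chloro in place of hydrogen on an aromatic carbon. This is the same kind of change as from compound 1 to compound 2, but the surroundings differ: in compound 4 the entering chloro is meta to a chloro group as well as para to a large group, whereas in compound 2 it is only para to a large group.

The step expected from compound 3 to compound 4 is a 2.5-fold lower number from compound 3 to compound 4 (0.40 log units; beyond the scatter), set a little smaller than the measured step because a 3.3-fold lower number from compound 1 to compound 2 (0.52 log units; beyond the scatter) was recorded on a different core. For compound 4 the estimated value in this assay is 220 nM, expected to fall between 80 nM and 600 nM.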

Compound 4, half-maximal inhibitory concentration: 1140 nM
Estimate against measurement, compound 4: 5.2-fold (0.71 log units) below; measured number outside the range, above it.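

In this assay, the chloro change does not carry over unchanged to the core of compound 3, where going to the 2,4-dichlorophenyl urea gives a 2.1-fold higher number from compound 3 to compound 4 (0.32 log units; beyond the scatter). The same change therefore moves the number in opposite directions on the two cores, and the two steps differ by more than the scatter allows: the same change on two cores in this assay, a 3.3-fold lower number (0.52 log units; beyond the scatter) from compound 1 to compound 2 and a 2.1-fold higher number (0.32 log units; beyond the scatter) from compound 3 to compound 4, 6.8-fold (0.83 log units) apart, beyond the scatter of two such steps. Among these compounds, this does not show what sets the steps apart: the comparison rests on only two pairs, and the core differs together with the surroundings of the entering chloro, which in compound 4 is meta to a chloro group and in compound 2 only para to a large group.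

Open, from the compounds shown here alone, is whether the same chloro, entering an unsubstituted phenyl urea on the core of compound 3, would lower the number as it does from compound 1 to compound 2. Also open, going by these compounds, is whether a fluoro or a methoxy group in the same place would follow chloro on either core.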